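Epimer of an inactive compound in DU-145 cytotoxicity

This account rests on a few compounds, and the source may have more. Where it says the series, first, only, none or still open, it means among the compounds named here.

Values in a functional assay on DU-145 cells (Homo sapiens) for cytotoxicity, read by MTT assay, with a stated time of 24 h; a lower number here means a stronger inhibitor, a higher number a weaker inhibitor:
- compound 1 `CC(=O)O[C@@]1(C)C/C=C2\O[C@H](C[C@@H]2C)C[C@]2(C)O[C@H]2C(=O)C(=C(C)C)CC1`: > 50000 nM
- compound 2 `CC(=O)O[C@@]1(C)CCC(=O)[C@H](C)CCC[C@]2(C)O[C@H]2C(=O)C(=C(C)C)CC1`: > 50000 nM
- compound 3 `CC(C)=C1CC[C@]2(C)CC[C@]3(O[C@H](C[C@H]3C)C[C@]3(C)O[C@H]3C1=O)O2`: > 50000 nM

All three entries are limits of the assay, not numbers. Compound 2 stands at a limit, > 50000 nM, so its true position is not known. The series as a whole offers only (the limit of > 50000 nM in this assay, at which 3 of the 3 values shown sit). For the measured compounds named here, no measured pair isolates a single structural change, and no compound can be ranked against another.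

Next is compound 4 `CC(=O)O[C@@]1(C)CCC(=O)[C@@H](C)CCC[C@]2(C)O[C@H]2C(=O)C(=C(C)C)CC1`, which keeps the atoms and bonds of compound 2: the two compounds have the same atoms and bonds and differ only in configuration as drawn: 1 of 4 stereo elements differ; a stereocentre at a saturated ring carbon is drawn R in compound 2 and S in compound 4. Going by the values given here, the one change is a stereocentre at a saturated ring carbon, drawn R in compound 2 and S in compound 4.

The expectation for this inversion rests on compound 2, which gives > 50000 nM, a limit. Measured compounds offer no sign that a single change of configuration brings a response in this assay. The expected change is none beyond the scatter: a number no higher from compound 2 to compound 4 (the limit leaves the size open). The most likely report is again a limit. For compound 4 the estimated value is 50000 nM, with an expected range of 25000 nM to 100000 nM.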

Compound 4, half-maximal inhibitory concentration: 43700 nM
Beside the measured number, compound 4's estimate is 1.1-fold (0.06 log units) above it; low and high end bracket the measured number.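

In this assay compound 4 gives 43700 nM, the only entry shown so far that is a number and not a limit. Compound 2 gives > 50000 nM, which is a limit. Inverting the stereocentre at a saturated ring carbon therefore yields a one-sided result, an at least 1.1-fold lower number from compound 2 to compound 4 (0.05 log units; that floor lies within the scatter), so this position now has a readable lower bound on the step but no upper one, and the comparison isolates this single centre: the fact that compounds 2 and 4 differ only in the configuration as drawn

For the compounds shown here, the true size of the step stays open, and so does whether configuration at this stereocentre matters at all in this assay, as the series still offers only one number to set against its limits: the limit of > 50000 nM in this assay, at which 3 of the 4 values shown sit. Also open is whether an amine or a carboxylic acid on the shared core, or a longer chain in place of the acetate, would give values clearly inside the measurable range of this assay, and whether the same inversion would then produce a step that can be read in full.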